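A few compounds are considered here, and "the series" means these few. Any claim that something is new, unique, unknown or untested is made for them only; others in the source may bear on it.

Compound 1 `COc1ccccc1-c1ccccc1NC(=O)[C@@H]1CCCN1C(=O)CCc1nc2ccccc2[nH]1` stands at the top of the two numbers in hand: in an assay on CHO cells for displacement of a labelled ligand from Orexin/Hypocretin receptor type 1 (Homo sapiens) (a higher number here means a weaker inhibitor, a lower number a stronger inhibitor), compound 1 gives 86 nM, the highest value measured. Compound 2 `Cc1ccc2c(c1)nc(SCC(=O)N1CCC[C@H]1C(=O)Nc1ccccc1-n1cccc1)n2C` differs from it in several places at once, so the two can only be set side by side. In this assay compound 2 gives 0.7 nM, and the gap between the two values lies well beyond the scatter. Going by the values given here, no pair of measured compounds differs in a single place, so the size of any one change cannot be read off the measured set.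

Compound 3 `O=C(Nc1ccccc1-c1ccccc1)[C@@H]1CCCN1C(=O)CCc1nc2ccccc2[nH]1` is compound 1 with a single change: hydrogen in place of methoxy on an aromatic carbon. The group that leaves sits on an aromatic carbon of a six-membered aromatic ring of carbon only, ortho to a large group. With nothing measured to anchor it, the expectation for this step is a modest move toward weaker inhibition, a step of a 2.3-fold higher number from compound 1 to compound 3 (0.37 log units; beyond the scatter), sized not far beyond the scatter. For compound 3 in this assay the estimate is 200 nM, expected to fall between 60 nM and 700 nM.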

Compound 3, inhibition constant: 40 nM
Estimate against measurement, compound 3: 5.0-fold (0.70 log units) above; the measured number lies below the stated range.
By their numbers in this assay, from the lowest: compound 2; then compound 3; then compound 1.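

Going from 2-methoxyphenyl to phenyl in this assay gives a 2.2-fold lower number from compound 1 to compound 3 (0.33 log units; beyond the scatter), the first change in the series that can be read on its own. The step is modest, but it shows that the methoxy on this aromatic carbon, ortho to a large group, is not required for the inhibition seen with compound 1, and that the series gains from its removal at this one position. Nothing in hand accounts for the direction of this step.

A single pair cannot separate two readings: that methoxy in particular is disfavoured at this carbon, or that any group larger than hydrogen is, and a fluorine atom, a hydroxyl, a methyl or an amine on the same carbon would tell these apart. Going by these compounds, compound 2, at 0.7 nM, differs from compound 3 in several places, so how much of the difference between their numbers belongs to the pyrrole-bearing ring, the sulfur-containing linker or the benzimidazole-type end of the molecule remains open.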